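Swapping a Fluorophenyl Amide for a Dimethylaminoethyl Amide

The source may hold more compounds than are shown below. What is called first, only, known or untested is meant among the compounds shown, and "the series" means these compounds.

Compound 2 `O=C(CCC(=O)OCCCCCCSc1ccc([N+](=O)[O-])c2nonc12)Nc1ccc(F)cc1` gives 8570 nM in an assay on isolated protein for inhibition of glutathione S-transferase P (Homo sapiens), with a stated time of 10 min (on this read-out lower numbers stand for stronger inhibition and higher numbers for weaker inhibition), and compound 1 `O=C(CCC(=O)OCCCCCCSc1ccc([N+](=O)[O-])c2nonc12)Nc1ccccc1F` gives 9890 nM, so the two numbers sit within the scatter of each other and neither stands apart. Among the compounds with values here, the only measured step, a 1.2-fold lower number from compound 1 to compound 2 (0.06 log units; within the scatter), exchanges one fluorophenyl for another and says nothing about replacing the ring altogether. Compound 3 `CN(C)CCNC(=O)CCC(=O)OCCCCCCSc1ccc([N+](=O)[O-])c2nonc12` carries exactly such a change: 2-(dimethylamino)ethyl in place of 4-fluorophenyl on an amide-type nitrogen. Within the data shown here, with no measured step bearing on this replacement, the number for compound 3 is expected to stay near that of compound 2, and a 1.4-fold higher number from compound 2 to compound 3 (0.15 log units; within the scatter) is the estimated step. The estimate for compound 3 is 12000 nM, ranging from 4000 nM to 40000 nM.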

Compound 3, half-maximal inhibitory concentration: 540 nM
The estimate for compound 3 lay 22-fold (1.35 log units) above the measured number; the whole stated range lies above it.
By their numbers in this assay, from the lowest: compound 3; then compounds 2 and 1 (each within the scatter of the next).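

The amide nitrogen proves sensitive to what it carries: in this assay, 2-(dimethylamino)ethyl in place of 4-fluorophenyl gives a large change (a 16-fold lower number from compound 2 to compound 3 (1.20 log units; beyond the scatter)), and in place of 2-fluorophenyl a large change too (an 18-fold lower number from compound 1 to compound 3 (1.26 log units; beyond the scatter)). The two fluorophenyl amides, within the scatter of each other, gave no sign of this. Nothing measured here explains the stronger inhibition. On these data alone, it stays open whether losing the ring or gaining the dimethylamino group matters more. A plain butyl group or a longer 3-(dimethylamino)propyl chain on the same nitrogen would bear on that question.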